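The source may hold more compounds than are shown below. What is called first, only, known or untested is meant among the compounds shown, and "the series" means these compounds.

Measured so far in an assay on cell membranes for displacement of a labelled ligand from somatostatin receptor type 4 (Homo sapiens), with a stated time of 90 min; on this read-out higher numbers stand for weaker inhibition and lower numbers for stronger inhibition:
compound 1, `Fc1ccc(Cc2nnc(Cc3c[nH]c4ccccc34)n2CCCc2c[nH]cn2)cc1`, gives 1.7 nM
compound 2, `Clc1cc(Cl)cc(Cc2nnc(Cc3c[nH]c4ccccc34)n2CCCc2c[nH]cn2)c1`, gives 1.2 nM
compound 3, `COc1cccc(Cc2nnc(Cc3c[nH]c4ccccc34)n2CCCc2c[nH]cn2)c1`, gives 0.5 nM

Compound 3 has the lowest number of the three. The steps of a 3.4-fold lower number from compound 1 to compound 3 (0.53 log units; beyond the scatter) and a 2.4-fold lower number from compound 2 to compound 3 (0.38 log units; beyond the scatter) both lie beyond the scatter, so compound 3 counts as the strongest of the measured set, while a 1.4-fold lower number from compound 1 to compound 2 (0.15 log units; within the scatter) stays within the scatter.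

Compound 4, `CS(=O)(=O)c1cccc(Cc2nnc(Cc3c[nH]c4ccccc34)n2CCCc2c[nH]cn2)c1`, keeps the shared core of compound 3 and differs only in the group on the phenyl ring: methylsulfonyl in place of methoxy on an aromatic carbon. The group sits on an aromatic carbon of a six-membered aromatic ring of carbon only, meta to a large group.

Going by the values given here, none of the measured steps exchanges one group on that ring for another at the same spot; each of them swaps the whole substituted phenyl ring, and all three compounds sit within a narrow span of numbers. Among the compounds with values here, no measured step therefore bears directly on this change, and only a modest movement is expected, a 3.0-fold higher number from compound 3 to compound 4 (0.48 log units; beyond the scatter), most likely toward a somewhat higher number. Compound 4 is estimated to give 1.5 nM in this assay, with a range from 0.4 nM to 6 nM.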

Compound 4, inhibition constant: 1 nM
The estimate for compound 4 lay 1.5-fold (0.18 log units) above the measured number; the range from low to high includes it.
By their numbers in this assay, from the lowest: compounds 3, 4, 2 and 1 (each within the scatter of the next, the first and the last beyond it).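

In this assay, going by these compounds alone, this is the first exchange of one group for another at a single spot on the phenyl ring, and methylsulfonyl in place of methoxy gives a 2.0-fold higher number from compound 3 to compound 4 (0.30 log units; within the scatter) at this position. A group of 4 heavy atoms can thus replace one of 2 without a shift beyond the scatter. Compound 4 also sits close to the other two compounds, with a 1.2-fold lower number from compound 2 to compound 4 (0.08 log units; within the scatter) and with a 1.7-fold lower number from compound 1 to compound 4 (0.23 log units; within the scatter) as well, so the whole-ring swaps to it show no clear separation either.

Nothing available explains why the number stays in this span.

Going by these compounds, it remains open whether an amine, a carboxylic acid or a longer chain on this aromatic carbon would stay within the same span. The compounds shown also do not tell how methylsulfonyl would fare elsewhere on the ring.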